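Extending the methyl group of compound 2 to propyl

The source may hold more compounds than are shown below. What is called first, only, known or untested is meant among the compounds shown, and "the series" means these compounds.

Measured in a functional assay on MDA cells (Homo sapiens) for inhibition, read by MTT assay, with a stated time of 48 h; on this read-out lower numbers stand for stronger inhibition and higher numbers for weaker inhibition:
compound 1 `O=C(COCCOc1no[n+]([O-])c1S(=O)(=O)c1ccccc1)NO` gives 15100 nM
compound 2 `CC(C)(COc1no[n+]([O-])c1S(=O)(=O)c1ccccc1)C(=O)NO` gives 9550 nM
compound 3 `O=C(/C=C/COc1no[n+]([O-])c1S(=O)(=O)c1ccccc1)NO` gives 47700 nM

Compound 2 holds the low end of these numbers, but shares it within the scatter: a 1.6-fold lower number from compound 1 to compound 2 (0.20 log units; within the scatter). Its only clear gap is a 5.0-fold higher number from compound 2 to compound 3 (0.70 log units; beyond the scatter). Compound 4 `CCCC(C)(COc1no[n+]([O-])c1S(=O)(=O)c1ccccc1)C(=O)NO` differs from compound 2 by ethyl in place of hydrogen on a saturated chain carbon, two bonds along the chain from a carbonyl carbon, which turns methyl into propyl. For the measured compounds named here, no measured step makes this change. Each one swaps the whole hydroxycarbamoyl-bearing chain, and even a 3.2-fold higher number from compound 1 to compound 3 (0.50 log units; beyond the scatter) is modest. A step within the scatter, with no firm direction, is therefore expected in this assay: a 1.2-fold lower number from compound 2 to compound 4 (0.08 log units; within the scatter). For compound 4 the estimated value is 8000 nM, with an expected range of 3500 nM to 19000 nM.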

Compound 4, half-maximal inhibitory concentration: 60500 nM
The estimate for compound 4 lay 7.6-fold (0.88 log units) below the measured number; measured number outside the range, above it.
By their numbers in this assay, from the lowest: compounds 2 and 1 (each within the scatter of the next); then compounds 3 and 4 (each within the scatter of the next).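

Turning methyl into propyl on the saturated chain carbon, two bonds along the chain from a carbonyl carbon, gives a 6.3-fold higher number from compound 2 to compound 4 (0.80 log units; beyond the scatter) in this assay and shows that this position does not tolerate every addition. The earlier steps shown here each swapped the whole hydroxycarbamoyl-bearing chain, whereas this one adds only an ethyl and still lies beyond the scatter. Nothing available explains this step.

Going by these compounds, whether a shorter ethyl or a longer butyl at this place would follow the same direction remains open. So does the effect of an amine or a hydroxyl at the end of the propyl.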